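Swapping the amide tail on compound 2

This account rests on a few compounds, and the source may have more. Where it says the series, first, only, none or still open, it means among the compounds named here.

Compound 1 `O=C(c1cccc(Nc2ncc(F)c(Nc3ccc(F)cc3)n2)c1)N1CCCCC1` gives 14800 nM in a functional assay on KB cells (Homo sapiens) for antiproliferative activity, read by sulforhodamine B assay, with a stated time of 3 days; on this read-out lower numbers stand for stronger inhibition of growth and higher numbers for weaker inhibition of growth.
Compound 2 `CN(C)CC(=O)Nc1cccc(Nc2ncc(F)c(Nc3ccc(F)cc3)n2)c1` gives 1260 nM in this assay.
Compound 3 `O=C(Nc1nccs1)c1cccc(Nc2ncc(F)c(Nc3ccc(F)cc3)n2)c1` gives only a limit, > 10000 nM in this assay.

Compound 2 gives the lowest of the two plain numbers; it stands apart from compound 1 by a 12-fold lower number from compound 1 to compound 2 (1.07 log units; beyond the scatter). Compound 4 `CN1CCC(C(=O)Nc2cccc(Nc3ncc(F)c(Nc4ccc(F)cc4)n3)c2)CC1` has not been measured. It differs from compound 2 in one place: 1-methylpiperidin-4-yl in place of (dimethylamino)methyl on a carbonyl carbon. For the measured compounds named here, two measured steps touch the same region of the molecule: a 12-fold lower number from compound 1 to compound 2 (1.07 log units; beyond the scatter) and an at least 7.9-fold higher number from compound 2 to compound 3 (0.89 log units; beyond the scatter) were both large. Yet here the entering group, like the leaving one, brings no donor, one acceptor and no charge, and the amide stays, so a step within the scatter is expected, a 1.2-fold higher number from compound 2 to compound 4 (0.08 log units; within the scatter). Compound 4 is therefore estimated to give about 1500 nM in this assay, somewhere between 500 nM and 5000 nM.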

Compound 4, concentration for 50% growth inhibition: 1700 nM
Compound 4: the middle estimate sits 1.1-fold (0.05 log units) below what was measured; measured number inside the range.
By their numbers in this assay, from the lowest: compounds 2 and 4 (each within the scatter of the next); then compound 1.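

In this assay, the carbonyl carbon takes 1-methylpiperidin-4-yl, with its six-membered non-aromatic ring, in place of (dimethylamino)methyl without a change that can be read (a 1.3-fold higher number from compound 2 to compound 4 (0.13 log units; within the scatter)). The new group also keeps the clear gap to the other two tails (in turn, an 8.7-fold lower number from compound 1 to compound 4 (0.94 log units; beyond the scatter) and an at least 5.8-fold lower number from compound 3 to compound 4 (0.76 log units; beyond the scatter)). Compound 3 stands here only as a limit: the limit of > 10000 nM in this assay, at which 1 of the 4 values shown sits.

Still open, on these data alone, is whether a carboxylic acid or a primary amine on this carbonyl carbon would be tolerated as well. A longer chain carrying the dimethylamino group also remains untested in the compounds shown.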